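A few compounds are considered here, and "the series" means these few. Any claim that something is new, unique, unknown or untested is made for them only; others in the source may bear on it.

Measured so far:

Compound 1 `c1ccc(-c2c3c(nn2C2CCC2)CCNCC3)cc1`: in an ADME assay on membranes from Cortex for displacement of a labelled ligand from Adrenergic receptor alpha-1 (Rattus norvegicus), read by radioligand binding, with a stated time of 60 min (a higher number here means a weaker inhibitor, a lower number a stronger inhibitor), compound 1 gives 500 nM.
Compound 2 `Cc1ccc(-c2c3c(nn2C(C)C)CCNCC3)cc1`: in this assay compound 2 gives 4 nM.

Compound 2 stands at the lower of the two numbers recorded so far. Its nearest neighbour is compound 1, whose number is far higher, and that gap lies beyond the scatter. For the measured compounds named here, the two measured compounds differ in more than one place, so no single-point step has yet been measured and no measured step can be borrowed for what follows.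

Compound 3 `CNc1ccc(-c2c3c(nn2C(C)C)CCNCC3)cc1` is the next compound to be measured in this assay. It differs from compound 2 in one place: methylamino in place of methyl on an aromatic carbon. With no measured step of this kind in hand, the expectation is a step of modest size, tending toward a higher number, of an extent that may or may not clear the scatter; the step expected is a 2.5-fold higher number from compound 2 to compound 3 (0.40 log units; beyond the scatter). For compound 3 the estimated result in this assay is 10 nM, with a range from 2 nM to 60 nM.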

Compound 3, inhibition constant: 16 nM
Estimate against measurement, compound 3: 1.6-fold (0.20 log units) below; the range from low to high includes it.
By their numbers in this assay, from the lowest: compound 2; then compound 3; then compound 1.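

For the compounds shown here, this is the first step that can be read at a single place: on an aromatic carbon para to a large group, methylamino in place of methyl gives a 4.0-fold higher number from compound 2 to compound 3 (0.60 log units; beyond the scatter) in this assay and is a modest change. The position is therefore not silent to substitution, yet compound 3 still reads 16 nM in this assay with methylamino there, a group that carries a nitrogen, a hydrogen-bond donor and a hydrogen-bond acceptor that methyl does not. No measurement in hand accounts for the rise, so the step describes this one pair and nothing wider.

Still open, on these data alone, is whether the step follows the nitrogen or simply the longer substituent, a question that a primary amine, dimethylamino, methoxy or ethyl at the same carbon would help to settle. Compound 1 differs from compound 2 in more than one place, so its number says nothing about this position, and the effect of the other groups on the shared core remains unread.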